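Removing a Methoxy Group from an Adenosine Receptor Ligand

This account rests on a few compounds, and the source may have more. Where it says the series, first, only, none or still open, it means among the compounds named here.

Compound 2 `COc1ccc(-c2nc(SCC(=O)c3sc(-c4ccc(Cl)cc4)nc3C)nc(N)c2C#N)cc1` is the starting point here. In an assay on membranes from CHO cells for displacement of a labelled ligand from adenosine receptor A1 (Homo sapiens), read by scintillation counting, with a stated time of 60 min, tested at 1 uM (a lower number here means less inhibition, a higher number more inhibition at the concentration tested (going by the name of the read-out)), compound 2 gives 1.2%. Among the compounds with values here, the only other measured compound, compound 1 `COc1ccc(-c2nc(C)c(C(=O)CSc3nc(N)c(C#N)c(-c4ccc(OC)cc4)n3)s2)cc1`, gives 9% in this assay. Compound 2 sits at the bottom of these two numbers, but the step of a number 7.8 percentage points lower from compound 1 to compound 2 (within the scatter) does not exceed the usual scatter, so the two compounds cannot really be told apart on this read-out.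

Compound 3 `Cc1nc(-c2ccc(Cl)cc2)sc1C(=O)CSc1nc(N)c(C#N)c(-c2ccccc2)n1` differs from compound 2 in one place: hydrogen in place of methoxy on an aromatic carbon. Within the data shown here, no measured step involves this particular change, hydrogen in place of methoxy. Among the measured compounds shown here, the single step available, chloro in place of methoxy on a different ring, was within the scatter, which gives no ground to expect movement here either. The step from compound 2 to compound 3 is therefore expected to be a number 1.8 percentage points higher from compound 2 to compound 3 (within the scatter). For compound 3 the estimate is 3%, with a range from 0% to 12%.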

Compound 3, a percentage reported as inhibition, at one concentration (the size of the read-out at that concentration, not a potency): 8.7%
Compound 3: middle estimate off by 5.7 percentage points, on the low side, and the stated range covers the measured number.
By their numbers in this assay, from the lowest: compounds 2, 3 and 1 (each within the scatter of the next).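

Going from 4-methoxyphenyl to phenyl, on the ring position para to a large group, gives in this assay a number 7.5 percentage points higher from compound 2 to compound 3 (within the scatter). Within the data shown here, this is the first reading of hydrogen in place of methoxy, and, like the earlier chloro step on the other ring, it stays within the usual scatter, so this methoxy group can be removed without a change that this read-out can distinguish. No supporting data shown here bear on the result.

From the compounds shown here alone, it remains open whether another group at this place, such as an amine, a carboxylic acid or a longer alkoxy chain, would move the read-out beyond the scatter. Going by these compounds, since this read-out comes from a single concentration, the potencies of compound 2 and compound 3 also remain open.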